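A few compounds are considered here, and "the series" means these few. Any claim that something is new, unique, unknown or untested is made for them only; others in the source may bear on it.

Among the measured compounds shown here, in a functional assay on Caco-2 cells (Homo sapiens), read by MTT assay, with a stated time of 48 h (on this read-out lower numbers stand for stronger inhibition and higher numbers for weaker inhibition), compound 2 (`CC[C@@H](C)[C@H](NC(=O)c1ccc(C(CC)(CC)c2ccc(OCC(O)C(C)(C)C)c(C)c2)n1CC)C(=O)O`) gives 3400 nM, the only true number so far. Compound 1 (`C=CCN(C)C(=O)c1ccc(C(CC)(CC)c2ccc(OCC(O)C(C)(C)C)c(C)c2)n1CC`) is reported only as a limit of the assay, > 50000 nM.

Compound 3 (`CCn1c(C(=O)Oc2ccc(CCO)cc2)ccc1C(CC)(CC)c1ccc(OCC(O)C(C)(C)C)c(C)c1`) keeps the shared core of compound 2 but changes what sits on a carbonyl carbon: a group of 10 heavy atoms (8 carbon, 2 oxygen; one six-membered aromatic ring of carbon only) in place of a group of 9 heavy atoms (6 carbon, 1 nitrogen, 2 oxygen; no ring), on a carbonyl carbon. The group that leaves, (1-carboxy-2-methylbutyl)amino, is the one that matters most here. For the measured compounds named here, the single measured step bearing on this change is large: an at least 14-fold lower number from compound 1 to compound 2 (1.16 log units; beyond the scatter), and it came with the arrival of that same group. Compound 3 gives the group up again, so a move towards weaker inhibition in this assay is expected. Going by the values given here, no measured compound carries the entering group, which leaves the size of the move uncertain. The estimated change is a 4.1-fold higher number from compound 2 to compound 3 (0.61 log units; beyond the scatter). For compound 3 the estimated value is 14000 nM, with an expected range from 3000 nM to 50000 nM.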

Compound 3, half-maximal inhibitory concentration: > 50000 nM
Compound 3 was reported as a limit; the forecaster's own chance of this, stated with the estimate: 35%; middle value at least 3.5-fold (0.55 log units) from the limit.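

Taking (1-carboxy-2-methylbutyl)amino off the carbonyl carbon in favour of the group with a six-membered aromatic ring gives an at least 14-fold higher number from compound 2 to compound 3 (1.16 log units; beyond the scatter). Compound 1 had shown this loss with allyl(methyl)amino, and compound 3 shows it with a very different group, so the measurable inhibition in this assay does not depend on one particular replacement. Among these compounds, only compound 2, which carries the (1-carboxy-2-methylbutyl)amino group, gives a true number, and the other two stop at a limit: the limit of > 50000 nM in this assay, at which 2 of the 3 values shown sit.

Going by these compounds, the step from compound 1 to compound 3 cannot be read, as both values are limits, and how far apart these two compounds lie stays unknown. On these data alone, it also remains open which part of the (1-carboxy-2-methylbutyl)amino group counts: the carboxylic acid or the branched chain, as a simple butylamine amide without the acid, or a glycine amide with the acid but without the chain, would separate the two.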